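This account rests on a few compounds, and the source may have more. Where it says the series, first, only, none or still open, it means among the compounds named here.

Compound 1, `O=C(Nc1cccc(-n2cc(-c3ccncc3)c(-c3ccc(Cl)c(O)c3)n2)c1)Nc1cccc(C(F)(F)F)c1`; compound 2, `COc1cc(-c2nn(-c3cccc(NC(=O)Nc4cc(C(F)(F)F)cc(C(F)(F)F)c4)c3)cc2-c2ccncc2)ccc1Cl`; compound 3, `COc1cc(-c2nn(-c3cccc(NC(=O)c4cccc(C(F)(F)F)c4)c3)cc2-c2ccncc2)ccc1Cl`.

In a functional assay on A498 cells (Homo sapiens) for inhibition, read by sulforhodamine B assay, with a stated time of 48 h (a lower number here means a stronger inhibitor of growth, a higher number a weaker inhibitor of growth), compound 1 gives only a limit of the assay, > 32500 nM, so no number is known for it. Compound 2 gives 1900 nM. Compound 3 gives 2780 nM, the higher of the two numbers, but the gap to compound 2 lies within the usual scatter, so the two cannot be told apart.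

Compound 4, `COc1cc(-c2nn(-c3cccc(NC(=O)Nc4ccc(Cl)c(Cl)c4)c3)cc2-c2ccncc2)ccc1Cl`, has not yet been measured in this assay. It differs from compound 3 in one place: (3,4-dichlorophenyl)amino in place of 3-(trifluoromethyl)phenyl on a carbonyl carbon. Compound 2 and compound 3 also differ from each other only in the group on this carbonyl carbon, and their two values lie within the scatter of each other. On that basis the step from compound 3 to compound 4 is expected to be small, in no clear direction, and not beyond the scatter: a 1.3-fold lower number from compound 3 to compound 4 (0.10 log units; within the scatter). Compound 4 is therefore expected to give about 2200 nM in this assay, with a range from 800 nM to 6500 nM.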

Compound 4, concentration for total growth inhibition: 4590 nM
For compound 4 the middle estimate is 2.1-fold (0.32 log units) below the measured one, within the range that was stated.
By their numbers in this assay, from the lowest: compounds 2, 3 and 4 (each within the scatter of the next, the first and the last beyond it). At a limit, above all of these: compound 1.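

In this assay, the group on this carbonyl carbon can be replaced by a rather different one without a clear effect: the step is a 1.7-fold higher number from compound 3 to compound 4 (0.22 log units; within the scatter) and stays within the scatter. The swap of 3-(trifluoromethyl)phenyl for (3,4-dichlorophenyl)amino adds a hydrogen-bond donor and exchanges trifluoromethyl for two chlorines, so this position accepts more than one kind of substituted phenyl group. The position is not wholly indifferent, however: compound 2 gives 1900 nM and compound 4 gives 4590 nM in the same assay, and these two values lie beyond the scatter of each other.

From the compounds shown here alone, whether this carbonyl carbon would also accept a group without an aromatic ring, such as a plain alkyl chain or a piperazine, remains open. Nothing measured for these compounds explains why their numbers fall where they do.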